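One iodo group in place of a nitrile

This account rests on a few compounds, and the source may have more. Where it says the series, first, only, none or still open, it means among the compounds named here.

Compound 1 `COC(=O)C1=C(C)N=C(C)/C(=C(\O)OC)C1c1ccc(I)cc1`: 22900 nM
Compound 2 `COC(=O)C1=C(C)N=C(C)/C(=C(\O)OC)C1c1cccc(C#N)c1`: 34.7 nM

In a functional assay (muscle tissue) with Cavia porcellus as the target (on this read-out lower numbers stand for an effect already at smaller amounts and higher numbers for an effect only at larger amounts of compound), compound 2 holds the lower of the two numbers, while compound 1 holds the higher. Compound 3 `COC(=O)C1=C(C)N=C(C)/C(=C(\O)OC)C1c1cccc(I)c1` has not yet been measured. It differs from compound 2 by a single change, iodo in place of cyano on an aromatic carbon.

Among the compounds with values here, only one measured step bears on this change: a 660-fold lower number from compound 1 to compound 2 (2.82 log units; beyond the scatter). That step altered both the group and its place on the ring, and the two compounds alone cannot separate these contributions. Compound 3 combines the iodo group of compound 1 with the ring place of compound 2, since its 3-iodophenyl group stands where compound 2 has its 3-cyanophenyl group. With the place unchanged, a move to a higher number in this assay is expected, but one much smaller than the measured step. The expected change is a 3.5-fold higher number from compound 2 to compound 3 (0.54 log units; beyond the scatter). Compound 3 is estimated at 120 nM, with an expected range from 20 nM to 800 nM.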

Compound 3, half-maximal effective concentration: 41.7 nM
Beside the measured number, compound 3's estimate is 2.9-fold (0.46 log units) above it; the range from low to high includes it.
By their numbers in this assay, from the lowest: compounds 2 and 3 (each within the scatter of the next); then compound 1.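

In this assay, the exchange of cyano for iodo on this aromatic carbon gives a 1.2-fold higher number from compound 2 to compound 3 (0.08 log units; within the scatter), so at this place on the ring the read-out does not separate the two groups, despite their different atoms. The step of a 660-fold lower number from compound 1 to compound 2 (2.82 log units; beyond the scatter) had changed both the group and its place, but with iodo held constant, 3-iodophenyl in place of 4-iodophenyl still gives a 550-fold lower number from compound 1 to compound 3 (2.74 log units; beyond the scatter) in this assay. This large step lies between two compounds that carry the same group at different places on the ring. No measurement accompanies these compounds that would account for this difference between the two places on the ring.

As far as these compounds go, what remains open is whether a nitrile placed where compound 1 carries its iodo group would bring the same large move to a higher number, or whether that move belongs to iodo alone. From the compounds shown here alone, it also remains open whether the match between nitrile and iodo holds for other groups at this place, such as an amine, a methoxy group or a carboxylic acid.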